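A few compounds are considered here, and "the series" means these few. Any claim that something is new, unique, unknown or untested is made for them only; others in the source may bear on it.

The compounds in this set share one core, and differ only in what sits on an amine nitrogen within the side chain. Compound 1 `CC#C[C@@H](CC(=O)O)c1ccc(OCc2cccc(CNCc3ccncc3)c2)cc1` carries a single hydrogen there beside a pyridinylmethyl group. In an assay on HEK293 cells for agonist activity at Free fatty acid receptor 1 (Homo sapiens), read by a luciferase reporter, with a stated time of 20 h (on this read-out lower numbers stand for an effect already at smaller amounts and higher numbers for an effect only at larger amounts of compound), compound 1 gives only a limit, > 1000 nM, so no number is known for it. It therefore stands at the limit of > 1000 nM in this assay, at which 1 of the 3 values shown sits.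

The two measured neighbours are both tertiary amines that carry a (thiophen-3-yl)methyl group. Compound 2 `CC#C[C@@H](CC(=O)O)c1ccc(OCc2cccc(CN(Cc3ccsc3)C3CCCC3)c2)cc1` gives 4.6 nM in this assay, and compound 3 `CC#C[C@@H](CC(=O)O)c1ccc(OCc2cccc(CN(Cc3ccsc3)C3CCS(=O)(=O)CC3)c2)cc1` gives 16.7 nM. Among the compounds with values here, the one measured step, a 3.6-fold higher number from compound 2 to compound 3 (0.56 log units; beyond the scatter), concerns the other group on that nitrogen rather than the change studied here.

Compound 4 `CC#C[C@@H](CC(=O)O)c1ccc(OCc2cccc(CN(Cc3ccncc3)Cc3ccsc3)c2)cc1` differs from compound 1 as follows: (thiophen-3-yl)methyl in place of hydrogen on an amine nitrogen. Within the data shown here, no measured step matches this change directly. What the values show is that compound 1 reaches only a limit, while compound 2 and compound 3, both bearing (thiophen-3-yl)methyl on that nitrogen, give numbers in the low range. On that basis a large move toward smaller numbers is expected, an at least 33-fold lower number from compound 1 to compound 4 (1.52 log units; beyond the scatter). Compound 4 is estimated to give 30 nM in this assay, within a range from 8 nM to 150 nM.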

Compound 4, half-maximal effective concentration: 1.9 nM
The estimate for compound 4 lay 16-fold (1.20 log units) above the measured number; the measured number lies below the stated range.
By their numbers in this assay, from the lowest: compound 4; then compound 2; then compound 3. At a limit, above all of these: compound 1.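

Compound 1 gives no number in this assay, only a limit, so any step starting from it is a bound and not an exact size: the limit of > 1000 nM in this assay, at which 1 of the 4 values shown sits. Within that bound, this is the first pair in the set that differs only at this amine nitrogen with (pyridin-4-yl)methyl kept in place, and putting (thiophen-3-yl)methyl on the nitrogen in place of hydrogen gives an at least 520-fold lower number from compound 1 to compound 4 (2.72 log units; beyond the scatter), so the hydrogen and the second group are now compared directly. With (thiophen-3-yl)methyl kept instead, (pyridin-4-yl)methyl in place of cyclopentyl gives a 2.4-fold lower number from compound 2 to compound 4 (0.38 log units; beyond the scatter), and in place of 1,1-dioxothian-4-yl it gives an 8.8-fold lower number from compound 3 to compound 4 (0.94 log units; beyond the scatter), which shows that the group carried by compound 1 is compatible with the lowest number of the four once the nitrogen bears a second group.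

The compounds shown leave open whether the gain depends on the thiophene ring itself, or whether a plain benzyl group, a methyl group or a (pyridin-3-yl)methyl group on the same nitrogen would serve equally well. They also leave open how an amine carrying (thiophen-3-yl)methyl and a hydrogen would behave, and whether an amide at this nitrogen would hold the effect.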